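Swapping Phenyl for Nitroimidazole: Expected Effect on Cell Toxicity

A few compounds are considered here, and "the series" means these few. Any claim that something is new, unique, unknown or untested is made for them only; others in the source may bear on it.

Compound 1 `CN1Cc2ccc(OCc3ccc([N+](=O)[O-])cc3)cc2[C@@H](O)C1`: > 50000 nM
Compound 2 `CN1Cc2ccc(OCCCc3ccccc3)cc2[C@@H](O)C1`: > 50000 nM
Compound 3 `CCCCCCCCCCCCOc1ccc2c(c1)[C@@H](O)CN(C)C2`: 18300 nM

These three compounds share one core and were tested in an ADME assay on Vero cells (Chlorocebus sabaeus) for cytotoxicity, read by sulforhodamine B assay, with a stated time of 72 h; a lower number here means a stronger inhibitor, a higher number a weaker inhibitor. For compound 1 the value > 50000 nM is a limit of the assay, not a number. For compound 2 the value > 50000 nM is likewise a limit. Only compound 3 gives an actual number, 18300 nM. Compound 2 therefore stands at the limit of > 50000 nM in this assay, at which 2 of the 3 values shown sit, together with compound 1. Compound 4 `CN1Cc2ccc(OCCCn3cnc([N+](=O)[O-])c3)cc2[C@@H](O)C1` has not yet been measured; it differs from compound 2 by 4-nitro-1H-imidazol-1-yl in place of phenyl on a saturated chain carbon, three bonds along the chain from an oxygen on an aromatic ring. Going by the values given here, no measured step between compounds exists here, so no shift beyond the scatter is expected, and the step is estimated as a number no higher from compound 2 to compound 4 (the limit leaves the size open). Compound 4 is expected to give about 50000 nM, within 20000 nM to 150000 nM, most likely again reported as a limit.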

Compound 4, half-maximal inhibitory concentration: > 50000 nM
Compound 4 was reported as a limit (the forecaster's own chance of this, stated with the estimate: 80%); the middle value sits exactly at the limit.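

In this assay compound 2 gives > 50000 nM, a limit and not a number. Going by these compounds alone, compound 4 gives > 50000 nM, also a limit, so no step from compound 2 to compound 4 can be read. Still open, going by these compounds, is whether 4-nitro-1H-imidazol-1-yl in place of phenyl changes the true value at all.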